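A few compounds are considered here, and "the series" means these few. Any claim that something is new, unique, unknown or untested is made for them only; others in the source may bear on it.

Measured compounds in a functional assay on HCT-116 cells (Homo sapiens) for inhibition, read by MTT assay, with a stated time of 48 h; a lower number here means a stronger inhibitor, a higher number a weaker inhibitor:
- compound 1 `CCC/C=C/C(=O)N(Cc1ccc(OC)c(O)c1)c1cc(OC)c(OC)c(OC)c1` gives 95 nM
- compound 2 `CCC(=O)N(Cc1ccc(OC)c(O)c1)c1cc(OC)c(OC)c(OC)c1` gives 61 nM
- compound 3 `C/C=C/C=C/C(=O)N(Cc1ccc(OC)c(O)c1)c1cc(OC)c(OC)c(OC)c1` gives 180 nM

Compound 3 has the highest of the three numbers. Its nearest neighbour is compound 1, with a 1.9-fold higher number from compound 1 to compound 3 (0.28 log units; within the scatter); the furthest is compound 2, with a 3.0-fold higher number from compound 2 to compound 3 (0.47 log units; beyond the scatter). The remaining pair, a 1.6-fold lower number from compound 1 to compound 2 (0.19 log units; within the scatter), stays inside the scatter.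

Compound 4 `COc1ccc(CN(C(=O)C[Se]C#N)c2cc(OC)c(OC)c(OC)c2)cc1O` has not yet been measured. It differs from compound 3 in one place: a group of 4 heavy atoms (2 carbon, 1 nitrogen, 1 selenium; no ring) in place of a group of 5 heavy atoms (5 carbon; no ring), on a carbonyl carbon. All three measured steps concern the same carbonyl carbon, and none of them moved the number far; the largest, a 3.0-fold higher number from compound 2 to compound 3 (0.47 log units; beyond the scatter), is only modest. Going by the values given here, no measured compound carries a group of this kind on that carbon, so the measured steps give only an indirect guide. The working expectation is that the change lands within the range already seen for exchanges on the carbonyl carbon, with a small downward tendency for compound 4, expressed as a 1.6-fold lower number from compound 3 to compound 4 (0.21 log units; within the scatter). Compound 4 is therefore estimated at 110 nM, with a broad range from 30 nM to 450 nM reflecting the lack of any close precedent.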

Compound 4, half-maximal inhibitory concentration: 310 nM
The estimate for compound 4 lay 2.8-fold (0.45 log units) below the measured number; low and high end bracket the measured number.
By their numbers in this assay, from the lowest: compounds 2, 1, 3 and 4 (each within the scatter of the next, the first and the last beyond it).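

In this assay, the carbonyl carbon now carries a group holding atoms other than carbon and hydrogen, a selenium atom and a nitrile, and exchanging penta-1,3-dien-1-yl for it stays inside the scatter (a 1.7-fold higher number from compound 3 to compound 4 (0.24 log units; within the scatter)). The same group separates from the other two chains, though both steps are only modest (a 3.3-fold higher number from compound 1 to compound 4 (0.51 log units; beyond the scatter); a 5.1-fold higher number from compound 2 to compound 4 (0.71 log units; beyond the scatter)), and the step from ethyl is the largest seen at this carbon. No available evidence bears on the origin of these differences.

The compounds shown leave open whether the selenium atom or the nitrile accounts for the step from ethyl, since neither occurs here without the other. From the compounds shown here alone, how a sulfur atom in place of selenium, or an amine or a carboxylic acid on this chain, would read in this assay also remains open.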